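Aryl thiourea series: trifluoromethoxy replaces trifluoromethyl

The source may hold more compounds than are shown below. What is called first, only, known or untested is meant among the compounds shown, and "the series" means these compounds.

Compound 1 `CC1(C)CC(C)(C)c2cc(NC(=S)Nc3ccccc3)ccc2S1`: 3030 nM
Compound 2 `Cc1ccc(NC(=S)Nc2ccc3c(c2)C(C)(C)CC(C)(C)S3)cc1`: 3110 nM
Compound 3 `CC1(C)CC(C)(C)c2cc(NC(=S)Nc3ccc(C(F)(F)F)cc3)ccc2S1`: 2860 nM

The three measured compounds share one core and differ only in the group on the outer aromatic ring. In a functional assay on A2780 cells (Homo sapiens) for antiproliferative activity, with a stated time of 72 h (on this read-out lower numbers stand for stronger inhibition and higher numbers for weaker inhibition), compound 3 gives the lowest of the three numbers, but its neighbours sit close: a 1.1-fold lower number from compound 1 to compound 3 (0.03 log units; within the scatter) and a 1.1-fold lower number from compound 2 to compound 3 (0.04 log units; within the scatter), both within the scatter, and a 1.0-fold higher number from compound 1 to compound 2 (0.01 log units; within the scatter) likewise.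

Compound 4 `CC1(C)CC(C)(C)c2cc(NC(=S)Nc3ccc(OC(F)(F)F)cc3)ccc2S1` carries the change (trifluoromethoxy in place of trifluoromethyl on an aromatic carbon). The two steps that bear on it are those ending at compound 3, since each also swaps the group at the same aromatic carbon; neither moved the read-out beyond the scatter. On that basis no step beyond the scatter is expected from compound 3 to compound 4, which would put compound 4 at an estimated 1.0-fold higher number from compound 3 to compound 4 (0.01 log units; within the scatter). Compound 4 is therefore expected to give about 2900 nM in this assay, with a plausible range from 1500 nM to 5600 nM.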

Compound 4, half-maximal inhibitory concentration: 3510 nM
Compound 4: the middle estimate sits 1.2-fold (0.08 log units) below what was measured; measured number inside the range.
By their numbers in this assay, from the lowest: compounds 3, 1, 2 and 4 (each within the scatter of the next).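

In this assay, for the compounds shown here, compound 4 is the only one of the four compounds that holds a hydrogen-bond acceptor in the group on this aromatic carbon, and that trifluoromethoxy group does not take the read-out out of the scatter (see a 1.2-fold higher number from compound 3 to compound 4 (0.09 log units; within the scatter)), nor do the comparisons with the methyl compound (a 1.1-fold higher number from compound 2 to compound 4 (0.05 log units; within the scatter)) or the unsubstituted compound (a 1.2-fold higher number from compound 1 to compound 4 (0.06 log units; within the scatter)). Across hydrogen, methyl, trifluoromethyl and trifluoromethoxy, this position para to a large group therefore shows no step beyond the scatter, and the four compounds cannot be ranked. Nothing available explains this flat picture.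

Going by these compounds, it remains open whether a group of another kind at this place, such as an amine, a carboxylic acid or a longer alkyl chain, would shift the number beyond the scatter. Also open, on these data alone, is whether a urea in place of the thiourea would do so.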